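Chain shortening on the ring nitrogen substituent

A few compounds are considered here, and "the series" means these few. Any claim that something is new, unique, unknown or untested is made for them only; others in the source may bear on it.

Among the measured compounds shown here, compound 2 `CCCCn1nnc2c(Br)cccc21` holds the higher of the two numbers measured so far. In a functional assay on cells for positive allosteric modulation of metabotropic glutamate receptor 2 (Homo sapiens), read by fluorescence and calcium flux, with a stated time of 30 min (on this read-out higher numbers stand for an effect only at larger amounts of compound and lower numbers for an effect already at smaller amounts), compound 2 gives 60 nM, while compound 1 `Brc1cccc2c1nnn2CC1CCCC1` gives 30 nM; the two values sit within the scatter of each other, so no order can be read between them. For the measured compounds named here, the step from compound 1 to compound 2, a 2.0-fold higher number from compound 1 to compound 2 (0.30 log units; within the scatter), is the only measured step and it concerns the same side of the shared core: propyl in place of cyclopentyl on a saturated chain carbon bound to an aromatic nitrogen.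

Compound 3 `CCCn1nnc2c(Br)cccc21` differs from compound 2 by hydrogen in place of methyl on a saturated chain carbon, three bonds along the chain from an aromatic nitrogen. Going by the values given here, the one step that bears on it altered the same substituent more extensively and stayed within the scatter, so for compound 3 a step in this assay of no more than the scatter is expected, in either direction.

On that basis the expected change from compound 2 to compound 3 is a 1.3-fold higher number from compound 2 to compound 3 (0.12 log units; within the scatter). Compound 3 is therefore estimated at 80 nM, with a range from 30 nM to 220 nM.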

Compound 3, half-maximal effective concentration: 270 nM
Beside the measured number, compound 3's estimate is 3.4-fold (0.53 log units) below it, outside the stated range (above it).
By their numbers in this assay, from the lowest: compounds 1 and 2 (each within the scatter of the next); then compound 3.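

In this assay the change from butyl to propyl gives a 4.5-fold higher number from compound 2 to compound 3 (0.65 log units; beyond the scatter) and so moves the number beyond the scatter, which the earlier step between cyclopentyl and propyl in the step list's wording did not do. Set against the substituent of compound 1, the shorter chain gives a 9.0-fold higher number from compound 1 to compound 3 (0.95 log units; beyond the scatter) and this wider gap shows that the substituents of compound 1 and compound 2 sit within the scatter of each other while a single methyl removed from the chain end of compound 2 is enough to separate compound 3 from both. The data on hand offer no explanation for this sensitivity at the chain end.

Open, from the compounds shown here alone, is whether a longer chain such as pentyl would stay within the scatter of compound 2 or move away from it, and whether ethyl or methyl in place of propyl would raise the number further. Also open, going by these compounds, is how an amine or a hydroxyl group at the end of the chain would read in this assay at this place on the shared core.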